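The source may hold more compounds than are shown below. What is called first, only, known or untested is meant among the compounds shown, and "the series" means these compounds.

Compound 1, `O=C(CCSc1nnc(-c2ccncc2)s1)Nc1ccccc1`, and compound 2, `CC(CSc1nnc(-c2ccncc2)s1)C(=O)NCc1ccc(Cl)cc1`, share one core and differ in the chain that carries the amide and in the group attached to the amide nitrogen. In an ADME assay on HepG2 cells (Homo sapiens) for cytotoxicity, with a stated time of 3 days (on this read-out higher numbers stand for lower toxicity in this test and lower numbers for higher toxicity in this test), compound 1 gives > 50000 nM, which is a limit of the test rather than a measured number. For compound 2 the entry in this assay reads "not determined" (no result reported), so it stands on no number of its own. Among the compounds shown, the only value is the limit of > 50000 nM in this assay, at which 1 of the 2 values shown sits, the limit reached by compound 1. Compound 3, `O=C(CCSc1nnc(-c2ccncc2)s1)NCc1ccc(Cl)cc1`, is the one still to be measured. It differs from compound 2 in a single place: hydrogen in place of methyl on a saturated chain carbon bound to a carbonyl carbon and a saturated chain carbon. For the measured compounds named here, no step between two measured compounds exists here, so nothing measured shows how such a change moves the read-out. In this assay no shift beyond the usual scatter is expected from this change, and a result at the limit again seems quite possible. Compound 3 is therefore expected to give roughly 60000 nM, with a likely range from 20000 nM to 200000 nM.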

Compound 3, half-maximal cytotoxic concentration: 15600 nM
For compound 3 the middle estimate is 3.8-fold (0.59 log units) above the measured one, and the stated range ends above it.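

In this assay, 4-chlorobenzyl in place of phenyl on the amide-type nitrogen, with the rest of the molecule unchanged, gives an at least 3.2-fold lower number from compound 1 to compound 3 (0.50 log units; beyond the scatter). For the compounds shown here, this is the first sign that the group on this nitrogen can move the read-out towards higher toxicity in this test, with compound 3 giving a real measured number of 15600 nM. The full size of the step remains unknown because compound 1 reaches only a limit of the test, so its true value is not given: the limit of > 50000 nM in this assay, at which 1 of the 3 values shown sits.

From the compounds shown here alone, with no number for compound 2, the step involving hydrogen in place of methyl on the saturated chain carbon cannot be read, so the effect of this change on the read-out remains unknown. A plain benzyl group on the same nitrogen would be needed to tell whether the shift follows the chlorine atom or the added carbon between the nitrogen and the ring, and a longer chain there is also left open.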